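Benzyloxycarbonyl to (benzyloxycarbonyl)methyl: compound 2 to compound 3

This account rests on a few compounds, and the source may have more. Where it says the series, first, only, none or still open, it means among the compounds named here.

In a functional assay on HCT-15 cells (Homo sapiens) for cytotoxicity, read by colorimetric assay and MTT assay (a higher number here means a weaker inhibitor, a lower number a stronger inhibitor), compound 1 (`COc1cc(OC)c2cc(-c3ccccc3)c(O)nc2c1`) gives 10000 nM as its half-maximal inhibitory concentration. Compound 2 (`COc1ccc(-c2cc3c(OC)cc(OC)cc3n(CC(=O)OCc3ccccc3)c2=O)cc1`) reads 10000 nM and stands level with compound 1, within the scatter. Among the compounds with values here, the series so far offers no measured step between compounds that differ in one place, so these two readings are the only guide.

Compound 3 (`COc1ccc(-c2cc3c(OC)cc(OC)cc3n(CCC(=O)OCc3ccccc3)c2=O)cc1`) differs from compound 2 at one place, with (benzyloxycarbonyl)methyl in place of benzyloxycarbonyl on a saturated chain carbon bound to an aromatic nitrogen. No measurement speaks to this change directly.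

In this assay no step beyond the scatter is expected and no direction is favoured, an expectation resting only on compound 1 at 10000 nM and compound 2 at 10000 nM and on the small size of the structural change. The expected move (no change at the digits printed from compound 2 to compound 3 (within the scatter)) is an estimate and should stay inside the scatter. For compound 3 the estimated value is 10000 nM (expected range 5000 nM to 20000 nM).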

Compound 3, half-maximal inhibitory concentration: 10000 nM
Compound 3: the middle estimate sits on the measured number at the digits printed; the measured number falls inside the stated range.
By their numbers in this assay, from the lowest: compounds 1, 2 and 3 (each within the scatter of the next).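

In this assay, within the data shown here, the exchange of benzyloxycarbonyl for (benzyloxycarbonyl)methyl on a saturated chain carbon bound to an aromatic nitrogen gives no change at the digits printed from compound 2 to compound 3 (within the scatter), the first one-place step that the series offers. Compounds 1 and 2 could only be set side by side as separate readings, whereas this pair isolates a single position and shows that this particular exchange leaves the read-out unmoved, a finding that holds for this one pair and implies no wider pattern. No supporting measurement is available to explain the result.

Among these compounds, because this step covers only two closely related groups, the notes cannot say whether this position is generally tolerant or whether the readout would respond to a larger change. Open questions are whether a free carboxylic acid in place of the benzyl ester, an amine at the end of the chain, or a longer chain carrying the same ester would shift the value in this assay, and a step beyond the scatter in any of these would be the first sign that this position matters.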